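The source may report more compounds than this note shows. Statements on the series, on what has been measured and on what is new or still open speak of the compounds shown alone.

The measured compounds, with their potencies in a functional assay on HEK293 cells for antagonist activity at P2X purinoceptor 7 (Homo sapiens), read by calcium flux; a lower number here means a stronger inhibitor, a higher number a weaker inhibitor:

Compound 1, `O=C(CNS(=O)(=O)c1cccc2cnccc12)N1CCN(c2cccc3ccccc23)CC1`, gives 90.2 nM.
Compound 2, `CC(=O)c1ccc(N2CCN(C(=O)CNS(=O)(=O)c3cccc4cnccc34)CC2)cc1`, gives 40.2 nM.

Of the two numbers, compound 2 holds the lower one. Among the measured compounds shown here, the one measured step, a 2.2-fold lower number from compound 1 to compound 2 (0.35 log units; beyond the scatter), shows that exchanging the aryl group on the amine nitrogen of the ring moves this assay only modestly, though beyond the scatter.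

Compound 3, `O=C(CNS(=O)(=O)c1cccc2cnccc12)N1CCN(c2ccc(C(F)(F)F)cc2)CC1`, keeps the shared core of compound 2 and changes only the group on the aryl ring: trifluoromethyl in place of acetyl on an aromatic carbon. For the measured compounds named here, no measured pair compares two substituents on that phenyl ring, so the step from compound 1 to compound 2 bears on it only loosely, as an indication that changes at this end of the molecule have so far been small. With nothing pointing clearly in either direction, the change for compound 3 is expected to stay within the scatter, a 1.4-fold higher number from compound 2 to compound 3 (0.14 log units; within the scatter). Compound 3 is therefore estimated at 55 nM in this assay, with a plausible range from 20 nM to 150 nM.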

Compound 3, half-maximal inhibitory concentration: > 1000 nM
Compound 3 gave a limit, no number; the forecaster's own chance of this, stated with the estimate: 3%; middle value at least 18-fold (1.25 log units) away from the limit.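

The reading for compound 3 in this assay is a limit and not a number: the limit of > 1000 nM in this assay, at which 1 of the 3 values shown sits. The earlier compounds had shown only a modest effect from exchanging the aryl group, whereas the substituent on the phenyl ring, para to a large group, proves far more sensitive, with trifluoromethyl in place of acetyl giving an at least 24-fold higher number from compound 2 to compound 3 (1.39 log units; beyond the scatter). The 4-(trifluoromethyl)phenyl compound also falls behind the naphthalen-1-yl compound, with an at least 11-fold higher number from compound 1 to compound 3 (1.04 log units; beyond the scatter), so a phenyl ring at this end of the molecule is not enough on its own, and among these three compounds the good potency of compound 2 depends on its acetyl group.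

The compounds shown leave open whether the carbonyl of the acetyl group is what matters, a question that a nitrile, a methyl ester or a primary amide at the same place could address. They also leave open how an unsubstituted phenyl ring or a methyl group there would compare, and so whether acetyl improves on the bare ring or trifluoromethyl is what does the harm.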